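The compounds below may be only part of what the source reports. "The series", "measured", "known", "first", "only" and "open" are said of these compounds alone.

Compound 1 `C=CC1=C(C(=O)NCCC)C(c2ccc(F)cc2)OC1` — in a functional assay on SW480 cells (Homo sapiens) for cytotoxicity, read by MTT assay, with a stated time of 24 h (on this read-out lower numbers stand for stronger inhibition and higher numbers for weaker inhibition), compound 1 gives > 100000 nM, which is a limit of the assay rather than a number.
Compound 2 `C=CC1=C(C(=O)NCc2ccccc2)C(c2ccc(OC)c(OC)c2)OC1` — compound 2 gives > 100000 nM, again a limit.
Compound 3 `C=CC1=C(C(=O)NCc2ccccc2)C(c2ccc(OC)cc2)OC1` — compound 3 gives 39500 nM.

For the measured compounds named here, compound 3 therefore stands as the only measured number; the other two values sit at the limit of > 100000 nM in this assay, at which 2 of the 3 values shown sit. Going by the values given here, the single measured step is an at least 2.5-fold lower number from compound 2 to compound 3 (0.40 log units; beyond the scatter), which concerns a methoxy on an aromatic carbon and leaves the amide side untouched.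

Compound 4 `C=CC1=C(C(=O)O)C(c2ccc(OC)cc2)OC1` differs from compound 3 by hydroxy in place of benzylamino on a carbonyl carbon. Among the compounds with values here, no measured step bears on this change, so its size cannot be read from the series; the only anchor is the weak activity of compound 3 itself at 39500 nM. Compound 4 is expected to show a step of a 2.5-fold higher number from compound 3 to compound 4 (0.40 log units; beyond the scatter), that is, a weaker number that may well fall back to the limit. The estimate for compound 4 is 100000 nM, with a range from 30000 nM to 300000 nM.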

Compound 4, half-maximal inhibitory concentration: > 100000 nM
Compound 4: no number, only a limit (the forecaster's own chance of this, stated with the estimate: 60%); the middle value lies on the limit itself.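

Replacing benzylamino with hydroxy on the carbonyl carbon gives an at least 2.5-fold higher number from compound 3 to compound 4 (0.40 log units; beyond the scatter) in this assay, the first step shown at this place; the earlier step concerned a methoxy on an aromatic carbon. Compound 4 gives > 100000 nM, which is a limit and not a number. The measurable value of compound 3 therefore depends on the benzylamino group as well as on the methoxy pattern, and compound 4 joins the others at the limit: the limit of > 100000 nM in this assay, at which 3 of the 4 values shown sit.

The compounds shown leave open which part of benzylamino counts, the amide hydrogen or the aromatic ring. As far as these compounds go, it also remains open whether a methyl ester or a longer phenethylamino chain at this place would keep, lower or raise the number seen for compound 3.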